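Replacing fluorine on compound 1 with a phosphorus group

The compounds below may be only part of what the source reports. "The series", "measured", "known", "first", "only" and "open" are said of these compounds alone.

In a functional assay on HL-60 cells (Homo sapiens) for inhibition, read by MTT assay, with a stated time of 72 h (on this read-out lower numbers stand for stronger inhibition and higher numbers for weaker inhibition), compound 1 (`Cc1nc(-c2cccc(F)c2)c(C(=O)N2CCN(c3cccc(Cl)c3)CC2)o1`) gives 33.7 nM. Its number cannot be separated from that of compound 3 (`COc1cc(OC)cc(N2CCN(C(=O)c3oc(C)nc3-c3cccc(F)c3)CC2)c1`), which gives 28.2 nM, while compound 2 (`Cc1nc(-c2ccccc2Cl)c(C(=O)N2CCN(c3cccc(Cl)c3)CC2)o1`) stands clearly higher at 132 nM. Compound 1 therefore sits in the lower part of this small set.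

The step of interest leads to compound 4 (`Cc1nc(-c2cccc(OP(=O)(O)O)c2)c(C(=O)N2CCN(c3cccc(Cl)c3)CC2)o1`), which has not yet been measured. The fluorine of compound 1 gives way as follows: a group of 5 heavy atoms (4 oxygen, 1 phosphorus; no ring) in place of one fluorine atom, on an aromatic carbon. The change lies on an aromatic carbon of a six-membered aromatic ring of carbon only, meta to a large group.

Two measured steps offer guidance. On the same aromatic substituent, the change to 2-chlorophenyl gave a 3.9-fold higher number from compound 1 to compound 2 (0.59 log units; beyond the scatter), so a change there can move the number beyond the scatter. The change to 3,5-dimethoxyphenyl on the amine side gave a 1.2-fold lower number from compound 1 to compound 3 (0.08 log units; within the scatter), which stays within the scatter and says little about the aromatic substituent. Among the measured compounds shown here, no measured compound carries a group like the one entering here, so any forecast is loose.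

A rise of at least modest size is expected in this assay. The expected change is a 3.0-fold higher number from compound 1 to compound 4 (0.47 log units; beyond the scatter). Compound 4 is estimated at 100 nM, with an expected range from 25 nM to 500 nM.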

Compound 4, half-maximal inhibitory concentration: > 1000 nM
Compound 4 gave a limit, no number; the forecaster's own chance of this, stated with the estimate: 10%; middle value at least 10-fold (1.00 log units) from the limit.
By their numbers in this assay, from the lowest: compounds 3 and 1 (each within the scatter of the next); then compound 2. At a limit, above all of these: compound 4.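

In this assay, among the compounds shown here, the aromatic carbon that carries fluoro in compound 1 turns out to be far less open to change than the earlier compounds could show, with the group of 5 heavy atoms (4 oxygen, 1 phosphorus) giving an at least 29-fold higher number from compound 1 to compound 4 (1.47 log units; beyond the scatter). For the compounds shown here, until now, the only change on this aromatic substituent was a 3.9-fold higher number from compound 1 to compound 2 (0.59 log units; beyond the scatter), which left open whether a much larger departure from fluoro could still be accepted here. Going by these compounds, compound 4 gives a limit and not a number, so its step has a lower bound only and its true size stays unknown: the limit of > 1000 nM in this assay, at which 1 of the 4 values shown sits.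

The compounds shown cannot tell whether the phosphorus, the oxygen atom joined to the ring, or the hydrogen-bond donors that enter with the group account for the loss, and they leave open whether hydroxyl, methoxy or a carboxylic acid on this carbon would keep compound 1's value of 33.7 nM. They also leave open whether the same group would give a similar result on compound 3, which carries 3,5-dimethoxyphenyl in place of 3-chlorophenyl.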